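The source may hold more compounds than are shown below. What is called first, only, known or untested is meant among the compounds shown, and "the series" means these compounds.

Three compounds share one core and differ only in the group on a carbonyl carbon. Compound 3 `O=C(c1ccccc1F)N1CC(c2nc(-c3cccc(Cl)c3)no2)C1` carries a 2-fluorophenyl there; in an assay on HEK293 cells for positive allosteric modulation of metabotropic glutamate receptor 5 (Homo sapiens), read by FLIPR (a higher number here means that more compound is needed for the effect, a lower number that less compound is needed), compound 3 gives > 10000 nM, which is a limit of the assay and not a number. Compound 1 `O=C(c1ccc(F)cc1)N1CC(c2nc(-c3cccc(Cl)c3)no2)C1`, with a 4-fluorophenyl, gives > 10000 nM, again a limit. Compound 2 `O=C(N1CCCCCC1)N1CC(c2nc(-c3cccc(Cl)c3)no2)C1`, with an azepan-1-yl, gives 47 nM. The steps of an at least 210-fold lower number from compound 1 to compound 2 (2.32 log units; beyond the scatter) and an at least 210-fold higher number from compound 2 to compound 3 (2.32 log units; beyond the scatter) show that replacing a fluorophenyl by an azepan-1-yl on this carbonyl carbon brings a large drop. Compound 4 `COC1CCN(C(=O)N2CC(c3nc(-c4cccc(Cl)c4)no3)C2)CC1` makes the change (4-methoxypiperidin-1-yl in place of 2-fluorophenyl on a carbonyl carbon), again a saturated ring in place of the fluorophenyl, so a large downward step is expected, an at least 83-fold lower number from compound 3 to compound 4 (1.92 log units; beyond the scatter). Compound 4 is therefore estimated at 120 nM, between 25 nM and 700 nM.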

Compound 4, half-maximal effective concentration: > 10000 nM
Compound 4 was reported as a limit; the forecaster's own chance of this, stated with the estimate: 10%; middle value at least 83-fold (1.92 log units) from the limit.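

A saturated ring on this carbonyl carbon is not enough by itself: the azepan-1-yl and the 4-methoxypiperidin-1-yl are both such rings, yet the change between them gives an at least 210-fold higher number from compound 2 to compound 4 (2.32 log units; beyond the scatter). The drop seen with compound 2 therefore belongs to that group, not to saturated rings in general. The steps from compound 1 and compound 3 to compound 4 cannot be read, because both ends of each are limits: the limit of > 10000 nM in this assay, at which 3 of the 4 values shown sit.

The compounds shown leave open whether ring size or the methoxy group matters more. A plain piperidin-1-yl on this carbonyl carbon would separate the two.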